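From furan-3-yl to thiophen-3-yl on a shared core

This account rests on a few compounds, and the source may have more. Where it says the series, first, only, none or still open, it means among the compounds named here.

Measured in a functional assay on HepG2 cells (Homo sapiens) for antiproliferative activity, read by XTT assay, with a stated time of 72 h (a lower number here means a stronger inhibitor, a higher number a weaker inhibitor), with these results:
Compound 1 `COc1ncnc2c1c(-c1cc3ccccc3o1)cn2[C@@H]1O[C@H](CO)[C@@H](O)[C@H]1O` gives > 20000 nM as a limit
Compound 2 `C#Cc1cn([C@@H]2O[C@H](CO)[C@@H](O)[C@H]2O)c2ncnc(SC)c12` gives > 15000 nM as a limit
Compound 3 `Nc1nc2c(c(-c3ccoc3)cn2[C@@H]2O[C@H](CO)[C@@H](O)[C@H]2O)c(=O)[nH]1` gives > 20000 nM as a limit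

Going by the values given here, none of these three compounds has yielded an actual number in this assay so far. In this assay compound 3 gives > 20000 nM and this is a limit, not a number.

The next compound to consider is compound 4 `Nc1nc2c(c(-c3ccsc3)cn2[C@@H]2O[C@H](CO)[C@@H](O)[C@H]2O)c(=O)[nH]1` which carries thiophen-3-yl in place of furan-3-yl on an aromatic carbon with the rest of the structure unchanged. The exchange lies on a five-membered aromatic ring with 1 nitrogen, part of a fused or bridged system of two rings.

Among the compounds with values here, no pair of measured compounds differs in one place, so no measured step is available as a guide. The expectation therefore rests on compound 3 alone, with its limit of > 20000 nM as the only reference. No step beyond the usual scatter is expected in this assay and compound 4 may well be reported as a limit too. The expected change is a number no higher from compound 3 to compound 4 (the limit leaves the size open) as an estimate only. For compound 4 the estimate is 20000 nM with an expected range from 7000 nM to 30000 nM in this assay until the measurement is known.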

Compound 4, half-maximal inhibitory concentration: > 20000 nM
Compound 4 was reported as a limit; the forecaster's own chance of this, stated with the estimate: 80%; the middle value sits exactly at the limit.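

Compound 3 and compound 4 are both reported only as limits, so no step can be read for the exchange of furan-3-yl for thiophen-3-yl in this assay: the limit of > 20000 nM in this assay, at which 3 of the 4 values shown sit.

The compounds shown leave open how these two groups compare in this assay, as none of the four gives an actual number there.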